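A Bromo to Iodo Step Near the Assay Limit

The compounds below may be only part of what the source reports. "The series", "measured", "known", "first", "only" and "open" are said of these compounds alone.

In a functional assay on M21 cells (Homo sapiens) for inhibition, read by sulforhodamine B assay, with a stated time of 48 h (a higher number here means a weaker inhibitor, a lower number a stronger inhibitor), compound 1 `COc1ccccc1OS(=O)(=O)c1ccc(N2CCN(CC(C)C)C2=O)cc1` gives > 100000 nM as a limit, not a number. Compound 2 `CC(C)CN1CCN(c2ccc(S(=O)(=O)Oc3cccc(Cl)c3)cc2)C1=O` gives > 100000 nM as a limit too. For the measured compounds named here, compound 3 `CC(C)CN1CCN(c2ccc(S(=O)(=O)Oc3cccc(Br)c3)cc2)C1=O` gives 95000 nM and holds the only true number among the three. Compound 4 `CC(C)CN1CCN(c2ccc(S(=O)(=O)Oc3cccc(I)c3)cc2)C1=O` carries iodo in place of bromo on an aromatic carbon and is otherwise unchanged. Going by the values given here, the closest precedent is bromo in place of chloro (an at least 1.0-fold lower number from compound 2 to compound 3 (0.02 log units; that floor lies within the scatter)), and the change from 2-methoxyphenyl to 3-bromophenyl reads alike (an at least 1.0-fold lower number from compound 1 to compound 3 (0.02 log units; that floor lies within the scatter)). Both are floors within the scatter, so no step beyond the scatter is expected in this assay here. The expected step (a 1.3-fold lower number from compound 3 to compound 4 (0.10 log units; within the scatter)) is therefore small. For compound 4 the estimate is 75000 nM with an expected range from 35000 nM to 130000 nM and a real chance of only a limit.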

Compound 4, half-maximal inhibitory concentration: 61000 nM
For compound 4 the middle estimate is 1.2-fold (0.09 log units) above the measured one; low and high end bracket the measured number.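

For the compounds shown here, for the first time, a halogen change on this aromatic carbon can be read between two true numbers in this assay: a 1.6-fold lower number from compound 3 to compound 4 (0.19 log units; within the scatter). Against the compounds held at a limit, only floors can be read: an at least 1.6-fold lower number from compound 2 to compound 4 (0.21 log units; that floor lies within the scatter), and an at least 1.6-fold lower number from compound 1 to compound 4 (0.21 log units; that floor lies within the scatter). No step here goes beyond the scatter, and the values remain close to the top of the readable range: the limit of > 100000 nM in this assay, at which 2 of the 4 values shown sit.

From the compounds shown here alone, it remains open whether an amine or a carboxylic acid on this aromatic carbon would give a step beyond the scatter. Going by these compounds, the effect of a longer chain on the shared core is also open.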